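The source may hold more compounds than are shown below. What is called first, only, known or untested is meant among the compounds shown, and "the series" means these compounds.

Measured so far in a functional assay on HCT-116 cells (Homo sapiens) for antiproliferative activity, read by MTT assay, with a stated time of 24 h; a higher number here means a weaker inhibitor, a lower number a stronger inhibitor:

Compound 1, `COc1ccc(C(=O)/C=C/c2cccc(F)c2)c2c1C=CC(C)(C)O2`, gives only a limit of the assay, > 10000 nM.
Compound 2, `COc1ccc(C(=O)/C=C/c2ccc(OC)c(OC)c2OC)c2c1C=CC(C)(C)O2`, likewise gives only a limit, > 10000 nM.
Compound 3, `COc1ccc(C(=O)/C=C/c2cccc(C(F)(F)F)c2)c2c1C=CC(C)(C)O2`, gives a number, 9710 nM.

Compound 1 therefore stands at the edge of what this assay can report rather than at a measured point; of the three compounds it is one of two that sit at the limit of > 10000 nM in this assay, at which 2 of the 3 values shown sit. Going by the values given here, the only step that can be sized, an at least 1.0-fold lower number from compound 1 to compound 3 (0.01 log units; that floor lies within the scatter), changes the same ring that is now to be exchanged, and its floor lies within the scatter, so that swap did nothing measurable.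

Compound 4 is `COc1ccc(C(=O)/C=C/c2ccco2)c2c1C=CC(C)(C)O2`. It arises from compound 1 by furan-2-yl in place of 3-fluorophenyl on a double-bonded chain carbon bound to a double-bonded chain carbon. No measured step exchanges one aromatic ring for another of a different ring size, so nothing shown bears directly on this change; the one step at this place gave no movement beyond the scatter. The expectation for compound 4 in this assay is therefore no step beyond the scatter, a step that the limit leaves unreadable from compound 1 to compound 4, with a fair chance that again only a limit is reported. The estimate for compound 4 is 15000 nM, ranging from 5000 nM to 60000 nM.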

Compound 4, half-maximal inhibitory concentration: > 10000 nM
Compound 4: only a limit was reported; the forecaster's own chance of this, stated with the estimate: 60%; the middle value lies beyond the limit too.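

Going by these compounds alone, compound 4 gives only a limit in this assay, > 10000 nM, and compound 1 also gives only a limit, so no step from compound 1 to compound 4 can be read. Most values shown now sit at this edge: the limit of > 10000 nM in this assay, at which 3 of the 4 values shown sit.

The compounds shown leave open whether furan-2-yl in place of 3-fluorophenyl changes the activity at all.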